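Swapping Nitro for Benzyloxy on a Thiophene Scaffold

The source may hold more compounds than are shown below. What is called first, only, known or untested is meant among the compounds shown, and "the series" means these compounds.

Compound 1 `CCOC(=O)c1cc(-c2cc(OC)c(OC)c(OC)c2)c(-c2ccc(OC)c([N+](=O)[O-])c2)s1` carries a nitro group on one of its aromatic rings, and in a functional assay on HT-1080 cells (Homo sapiens) for antiproliferative activity, read by MTT assay, with a stated time of 72 h (a lower number here means a stronger inhibitor, a higher number a weaker inhibitor), compound 1 gives 12700 nM. Compound 2 `CCOC(=O)c1cc(-c2cc(OC)c(OC)c(OC)c2)c(-c2ccc(OC)c(OCc3ccccc3)c2)s1` is its partner in which (benzyloxy in place of nitro on an aromatic carbon). For compound 2 this assay reaches only a limit, > 100000 nM. The step of an at least 7.8-fold higher number from compound 1 to compound 2 (0.89 log units; beyond the scatter) therefore shows a clear loss of activity, although how far it goes cannot be told because of the limit of > 100000 nM in this assay, at which 1 of the 3 values shown sits.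

Compound 3 `COc1ccc(-c2ccsc2-c2cc(OC)c(OC)c(OC)c2)cc1[N+](=O)[O-]` keeps the nitro group but sits on a different core; the difference between the core of compound 3 and the core of compound 1 is not broken down here. In this assay, within the data shown here, compound 3 gives 8040 nM, and this number and the one for compound 1 lie within the usual scatter of each other.

Compound 4 `COc1ccc(-c2ccsc2-c2cc(OC)c(OC)c(OC)c2)cc1OCc1ccccc1` has not yet been measured. It stands to compound 3 as compound 2 stands to compound 1: benzyloxy in place of nitro on an aromatic carbon, and the surroundings of the change are the same in both pairs, so this is the same change made a second time.

Among the measured compounds shown here, since the first instance of this change produced an at least 7.8-fold higher number from compound 1 to compound 2 (0.89 log units; beyond the scatter), a loss of similar size is expected here, written as an 8.7-fold higher number from compound 3 to compound 4 (0.94 log units; beyond the scatter). For compound 4 the estimate is 70000 nM, with a range from 25000 nM to 300000 nM, and there is a real chance that this assay will again report only a limit.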

Compound 4, half-maximal inhibitory concentration: > 100000 nM
Compound 4 was reported as a limit (the forecaster's own chance of this, stated with the estimate: 40%); at least 1.4-fold (0.15 log units) between middle value and limit.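

In this assay the swap of nitro for benzyloxy gives an at least 12-fold higher number from compound 3 to compound 4 (1.09 log units; beyond the scatter) and so loses activity on the second core, as it did on the first. In these two pairs, then, the direction of the change carries over from one core to the other, and the two steps can be set side by side: the same change on two cores in this assay, an at least 7.8-fold higher number (0.89 log units; beyond the scatter) from compound 1 to compound 2 and an at least 12-fold higher number (1.09 log units; beyond the scatter) from compound 3 to compound 4; the limit leaves it open whether they differ. What stays hidden is the true size of either loss, and with it whether one core bears the change better than the other, because compound 2 and compound 4 are both reported only as limits: the limit of > 100000 nM in this assay, at which 2 of the 4 values shown sit.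

The compounds shown leave open whether the loss belongs to benzyloxy in particular or would follow any replacement of nitro at this place, a question that a hydroxyl, an amine or an ethoxy group on the same two cores could begin to answer. They also leave open whether an amine or a carboxylic acid on the added benzene ring of the benzyloxy group would bring the numbers back within the range of the assay, where the two cores could be compared directly.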